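From methylsulfonyl to benzylsulfamoyl on the shared core

This account rests on a few compounds, and the source may have more. Where it says the series, first, only, none or still open, it means among the compounds named here.

Measured so far in an ADME assay on CHO cells (Cricetulus griseus) for cytotoxicity, read by MTT assay; on this read-out lower numbers stand for stronger inhibition and higher numbers for weaker inhibition:
compound 1 `CS(=O)(=O)c1cccc(Nc2ccc3nccc(-c4ccncc4)c3n2)c1` (> 50000 nM)
compound 2 `O=S(=O)(c1cccc(-c2ccc3nccc(-c4ccncc4)c3n2)c1)N1CCC(O)CC1` (8000 nM)
compound 3 `C[C@@H]1CN(S(=O)(=O)c2cccc(-c3ccc4nccc(-c5ccncc5)c4n3)c2)C[C@H](C)N1` (6000 nM)

Compound 1 has no number in this assay, only a limit (the limit of > 50000 nM in this assay, at which 1 of the 3 values shown sits). Compound 4 `O=S(=O)(NCc1ccccc1)c1cccc(Nc2ccc3nccc(-c4ccncc4)c3n2)c1` carries benzylamino in place of methyl on a sulfonyl sulfur. Among the measured compounds shown here, the one measured step, a 1.3-fold lower number from compound 2 to compound 3 (0.12 log units; within the scatter), swaps one group on a sulfonyl sulfur for another, and it gives only weak guidance. Compound 2 (8000 nM) and compound 3 (6000 nM) also hold a nitrogen group on that sulfur, yet they differ from compound 4 elsewhere too. A lower number in this assay is therefore expected, though a second limit remains possible. The estimated change is an at least 2.5-fold lower number from compound 1 to compound 4 (0.39 log units; beyond the scatter) (a rough expectation). For compound 4 the estimate is 20000 nM (expected range 6000 nM to 50000 nM).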

Compound 4, half-maximal inhibitory concentration: > 50000 nM
Compound 4: a limit, no number; the forecaster's own chance of this, stated with the estimate: 35%; middle value at least 2.5-fold (0.39 log units) away from the limit.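

In this assay compound 1 and compound 4 each give a limit rather than a number, so the step between them cannot be read: the limit of > 50000 nM in this assay, at which 2 of the 4 values shown sit.

From the compounds shown here alone, whether benzylamino in place of methyl on a sulfonyl sulfur changes the read-out at all stays open.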